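This account rests on a few compounds, and the source may have more. Where it says the series, first, only, none or still open, it means among the compounds named here.

Of the compounds shown here, three sharing one core have been measured in a functional assay on KB cells (Homo sapiens) for cytotoxicity; a higher number here means that more compound is needed for the effect, a lower number that less compound is needed. Compound 1 (`COC1=C(C)C(=O)/C(=C(O)/C=C/c2ccc(OC)cc2)C(=O)C1(C)C`), with a 4-methoxyphenyl group, gives 3.6 ug/mL and compound 2 (`COC1=C(C)C(=O)/C(=C(O)/C=C/c2cccc(OC)c2)C(=O)C1(C)C`), with a 3-methoxyphenyl group, gives 3.3 ug/mL on the same scale. Compound 3 (`COC1=C(C)C(=O)/C(=C(O)/C=C/c2ccccc2OC)C(=O)C1(C)C`), with a 2-methoxyphenyl group, gives 3.3 ug/mL and so stands level with compound 2 and within the scatter of compound 1.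

The next structure is compound 4 (`COC1=C(C)C(=O)/C(=C(O)/C=C/c2ccc(O)cc2)C(=O)C1(C)C`), which has 4-hydroxyphenyl in place of 2-methoxyphenyl on a double-bonded chain carbon bound to a double-bonded chain carbon.

Going by the values given here, three measured steps bear on this change, though only indirectly: a 1.1-fold lower number from compound 1 to compound 2 (0.04 log units; within the scatter) and a 1.1-fold lower number from compound 1 to compound 3 (0.04 log units; within the scatter) and also no change at the digits printed from compound 2 to compound 3 (within the scatter) (each exchanges one methoxyphenyl for another). None of them replaces a methoxyphenyl with a hydroxyphenyl, so the data hold no direct measure of this exchange. Given how small those steps are, no step beyond the scatter is expected in this assay, and no direction is favoured, although the range must stay wide. The estimate amounts to no change at the digits printed from compound 3 to compound 4 (within the scatter) as the expected step. Compound 4 is estimated at 3.3 ug/mL with an expected range (1.4 ug/mL to 8 ug/mL).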

Compound 4, concentration for half-maximal effect: 3.8 ug/mL
Estimate against measurement, compound 4: 1.2-fold (0.06 log units) below, within the range that was stated.
By their numbers in this assay, from the lowest: compounds 2, 3, 1 and 4 (each within the scatter of the next).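

Going by these compounds alone, until this result, every exchange at this place, on a double-bonded chain carbon bound to a double-bonded chain carbon, had swapped one methoxyphenyl group for another; compound 4 instead has hydrogen in place of methyl on the oxygen on the aromatic ring, and in this assay that exchange gives (a 1.1-fold higher number from compound 1 to compound 4 (0.02 log units; within the scatter)). The exchanges of the other two methoxyphenyl groups for 4-hydroxyphenyl give (a 1.2-fold higher number from compound 3 to compound 4 (0.06 log units; within the scatter)) and (a 1.2-fold higher number from compound 2 to compound 4 (0.06 log units; within the scatter)), so the hydrogen-bond donor that enters with the 4-hydroxyphenyl group comes with no step beyond the scatter in this set of four compounds. Nothing available explains why these steps are so small.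

The compounds shown leave open whether 2-hydroxyphenyl or 3-hydroxyphenyl would behave like the 4-hydroxyphenyl group, and whether an amine or a carboxylic acid on the aromatic ring, or a longer chain on its oxygen, would stay within the scatter as well. They also leave open what an exchange elsewhere on the shared core would do, since all four compounds differ only in this one aromatic group.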